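Swapping a Methyl for Fluorine on the Aryl Ring

The source may report more compounds than this note shows. Statements on the series, on what has been measured and on what is new or still open speak of the compounds shown alone.

Of the compounds shown here, three sharing one core have been tested in a functional assay on HeLa cells (Homo sapiens) for inhibition, read by MTT assay, with a stated time of 24 h; a lower number here means a stronger inhibitor, a higher number a weaker inhibitor. Compound 1 `CCOC(=O)C1=Cc2ccccc2OC1(OCc1cc(-c2ccc(C)cc2)no1)C(F)(F)F` carries an ethyl ester and a 4-methylphenyl group; in this assay compound 1 reaches only the limit > 150000 nM. Compound 2 `CCOC(=O)C1=Cc2ccccc2OC1(OCc1cn(-c2cccc(OC)c2)nn1)C(F)(F)F` likewise reaches only the limit > 150000 nM. For the measured compounds named here, compound 3 `Cc1ccc(-c2cc(COC3(C(F)(F)F)Oc4ccccc4C=C3C(=O)O)on2)cc1` is the carboxylic acid of compound 1, and in this assay compound 3 gives 33400 nM, the only measured number among the three. Going by the values given here, the single measured step, an at least 4.4-fold lower number from compound 1 to compound 3 (0.65 log units; beyond the scatter), shows that removing the ethyl matters, while the limit of > 150000 nM in this assay, at which 2 of the 3 values shown sit, is the bound at which the other two compounds sit.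

Compound 4 `O=C(O)C1=Cc2ccccc2OC1(OCc1cc(-c2ccc(F)cc2)no1)C(F)(F)F` differs from compound 3 at one place: fluoro in place of methyl on an aromatic carbon. Among the compounds with values here, none of the measured steps touches this position, so the expected step is a 1.0-fold higher number from compound 3 to compound 4 (0.02 log units; within the scatter), nothing beyond the scatter. Compound 4 is therefore estimated at 35000 nM, with a range from 12000 nM to 110000 nM.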

Compound 4, half-maximal inhibitory concentration: > 150000 nM
Compound 4: a limit, no number; the forecaster's own chance of this, stated with the estimate: 20%; middle value at least 4.2-fold (0.63 log units) from the limit.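

For the compounds shown here, this position on the aromatic ring, which no earlier step touched, turns out to matter: the swap of 4-methylphenyl for 4-fluorophenyl gives an at least 4.4-fold higher number from compound 3 to compound 4 (0.65 log units; beyond the scatter) in this assay. As far as these compounds go, the free carboxylic acid is therefore not enough by itself, as compound 4 keeps that acid and still gives only a limit rather than a number, so the true size of this step remains unknown. Compound 3 is now the only one of the four compounds with a measured number, which leaves very little to compare: the limit of > 150000 nM in this assay, at which 3 of the 4 values shown sit.

The compounds shown leave open whether the methyl group is specifically needed at this position, or whether plain hydrogen, chlorine, a methoxy group or a longer chain such as ethyl would also give a measurable number. They also leave open how an amine there would read.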